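Second instance of the methylbenzyl-to-fluorobenzyl swap

The source may hold more compounds than are shown below. What is called first, only, known or untested is meant among the compounds shown, and "the series" means these compounds.

Compound 1 `Cc1ccc(Cn2c(/C=C3\SC(=S)N(CC(=O)O)C3=O)nc3cc(Cl)ccc32)cc1` and compound 2 `Cc1ccc(Cn2c(/C=C3\SC(=S)N(CC(=O)O)C3=O)nc3ccc(Cl)cc32)cc1` are built from the same atoms joined differently; the difference between the two cores is not broken down here. In a functional assay on A549 cells (Homo sapiens) for cytotoxicity, read by MTT assay, with a stated time of 48 h (a higher number here means a weaker inhibitor, a lower number a stronger inhibitor), compound 1 gives 38600 nM and compound 2 gives 9970 nM. Compound 3 `O=C(O)CN1C(=O)/C(=C/c2nc3cc(Cl)ccc3n2Cc2ccccc2F)SC1=S` carries, relative to compound 1, (2-fluorophenyl in place of 4-methylphenyl on a saturated chain carbon bound to an aromatic nitrogen). In this assay compound 3 gives 5640 nM, and the step of a 6.8-fold lower number from compound 1 to compound 3 (0.84 log units; beyond the scatter) lies beyond the scatter. Compound 2 stands second highest of the three numbers; against compound 3 it lies within the scatter, against compound 1 beyond it.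

Compound 4 `O=C(O)CN1C(=O)/C(=C/c2nc3ccc(Cl)cc3n2Cc2ccccc2F)SC1=S` is not yet measured. It stands to compound 2 as compound 3 stands to compound 1: 2-fluorophenyl in place of 4-methylphenyl on a saturated chain carbon bound to an aromatic nitrogen. The place is the same word for word in both pairs, so this is the same change, made on the core of compound 2 rather than the core of compound 1. Within the data shown here, only one measured instance of it exists, the step from compound 1 to compound 3, and a single pair on a different core is a thin basis.

Compound 4 in this assay is expected at 2500 nM, with a range from 900 nM to 7000 nM, because the same change on compound 1 gave a 6.8-fold lower number from compound 1 to compound 3 (0.84 log units; beyond the scatter). The expected step from compound 2 is a 4.0-fold lower number from compound 2 to compound 4 (0.60 log units; beyond the scatter), set smaller than the measured one as it rests on one pair only.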

Compound 4, half-maximal inhibitory concentration: 26900 nM
Compound 4: middle estimate off by 11-fold (1.03 log units), on the low side; the whole stated range lies below it.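

On the core of compound 2, 2-fluorophenyl in place of 4-methylphenyl gives a 2.7-fold higher number from compound 2 to compound 4 (0.43 log units; beyond the scatter) in this assay, so the lower number seen on the core of compound 1 does not carry over to this core. The two instances of the change run in opposite directions, and the gap between them exceeds what repeat measurements would explain: the same change on two cores in this assay, a 6.8-fold lower number (0.84 log units; beyond the scatter) from compound 1 to compound 3 and a 2.7-fold higher number (0.43 log units; beyond the scatter) from compound 2 to compound 4, 18-fold (1.27 log units) apart, beyond the scatter of two such steps. This shows that, for these two pairs, the outcome of the swap depends on the core it is made on, but with one pair per core it does not show which feature of the cores is responsible, nor what the change would do on any third core.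

The compounds shown leave open how a plain benzyl group, placed on the same saturated chain carbon bound to an aromatic nitrogen, would compare on the two cores, which would help show whether the 4-methylbenzyl or the 2-fluorobenzyl group drives the reversal. They also leave open whether the same reversal would appear with a methyl ester in place of the carboxylic acid.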